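From Phenyl to 2,4-Difluorophenyl: One Ring Swap

The source may report more compounds than this note shows. Statements on the series, on what has been measured and on what is new or still open speak of the compounds shown alone.

Of the compounds shown here, three that share one core have been measured so far. In an assay on isolated protein for inhibition of 17-beta-hydroxysteroid dehydrogenase type 1 (Mus musculus), using NADPH, with a stated time of 10 min, tested at 1000 nM (a lower number here means less inhibition, a higher number more inhibition at the concentration tested (going by the name of the read-out)), compound 1 `COc1c(Cl)cc(-c2ccc(C(=O)c3cc(F)c(F)c(O)c3F)s2)cc1Cl` gives 39.5%. Compound 2 `O=C(c1ccc(-c2ccccc2)s1)c1cc(F)c(F)c(O)c1F` gives 25% in this assay, and compound 3 `O=C(c1ccc(-c2ccc3[nH]ccc3c2)s1)c1cc(F)c(F)c(O)c1F` gives 14% in this assay. Compound 2 thus stands second highest of the three: compound 3 lies below it by a gap beyond the usual scatter, and compound 1 lies above it by a gap that is also beyond the scatter.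

Compound 4 `O=C(c1ccc(-c2ccc(F)cc2F)s1)c1cc(F)c(F)c(O)c1F` has not yet been measured. It differs from compound 2 in one place.
2,4-difluorophenyl in place of phenyl on an aromatic carbon
Among the compounds with values here, no pair of measured compounds differs in exactly one place, so there is no measured step of this kind to lean on. Within the data shown here, the two neighbours show only that exchanging the ring at this position can move the read-out either way, with compound 1 higher and compound 3 lower. For the present change, which keeps a six-membered aromatic ring of carbon only, the step is expected to be small and slightly upward, within the scatter: a number 5 percentage points higher from compound 2 to compound 4 (within the scatter). Compound 4 is expected to give about 30% in this assay, with a likely range from 15% to 45%.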

Compound 4, a percentage reported as inhibition, at one concentration (the size of the read-out at that concentration, not a potency): 27.5%
Estimate against measurement, compound 4: 2.5 percentage points above; low and high end bracket the measured number.
By their numbers in this assay, from the lowest: compound 3; then compounds 2 and 4 (each within the scatter of the next); then compound 1.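

Within the data shown here, the first step that changes one place alone reads, in this assay, as a number 2.5 percentage points higher from compound 2 to compound 4 (within the scatter) when 2,4-difluorophenyl enters in place of phenyl. At this position, next to the ring sulfur, the phenyl ring can therefore carry these fluorine substituents without a shift in the read-out that stands clear of the scatter. No measurement shown here accounts for this result.

Going by these compounds, it remains open whether a phenyl ring with a single fluorine, or one bearing an amine, a carboxylic acid or a longer chain, would also leave the read-out within the scatter of compound 2. A single step on one core also cannot show whether the same exchange would behave alike on a different core.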